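Trimming the Ether Side Chain by One More Carbon

The source may report more compounds than this note shows. Statements on the series, on what has been measured and on what is new or still open speak of the compounds shown alone.

Compound 3 `C=CCc1cc(OC)c(OC(C)C(OCC)c2ccc(O)c(OC)c2)c(OC)c1` gives 332 nM in an assay on HEK293 cells for agonist activity at transient receptor potential cation channel subfamily M member 8 (Homo sapiens), read by fluorescence and calcium flux, with a stated time of 5 min (a lower number here means that less compound is needed, a higher number that more compound is needed for the effect), the highest of the three numbers in hand. Compound 1 `C=CCc1cc(OC)c(OC(C)C(OCCOCCCC)c2ccc(O)c(OC)c2)c(OC)c1` gives 153 nM, and compound 2 `C=CCc1cc(OC)c(OC(C)C(OCCCCCCCCCC)c2ccc(O)c(OC)c2)c(OC)c1` gives 66 nM. Compound 4 `C=CCc1cc(OC)c(OC(C)C(OC)c2ccc(O)c(OC)c2)c(OC)c1` differs from compound 3 by hydrogen in place of methyl on a saturated chain carbon bound to an oxygen on a saturated carbon, so the ethoxy group becomes a methoxy group. Within the data shown here, the steps that bear on this are a 5.0-fold higher number from compound 2 to compound 3 (0.70 log units; beyond the scatter) and a 2.2-fold higher number from compound 1 to compound 3 (0.34 log units; beyond the scatter): each time the chain on that carbon was shortened, the number rose. Removing one more carbon is expected to push the number up again by a smaller amount, and the step is estimated at a 1.4-fold higher number from compound 3 to compound 4 (0.13 log units; within the scatter). Compound 4 is therefore estimated at 450 nM, within a range from 200 nM to 1000 nM.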

Compound 4, half-maximal effective concentration: 3450 nM
For compound 4 the middle estimate is 7.7-fold (0.88 log units) below the measured one; the whole stated range lies below it.
By their numbers in this assay, from the lowest: compound 2; then compound 1; then compound 3; then compound 4.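

In this assay, among these compounds, the change from ethyl to methyl, a loss of one carbon, gives a 10-fold higher number from compound 3 to compound 4 (1.02 log units; beyond the scatter), a large step where the earlier steps at this position were modest. The longer chains widen the gap further, with a 52-fold higher number from compound 2 to compound 4 (1.72 log units; beyond the scatter) and a 23-fold higher number from compound 1 to compound 4 (1.35 log units; beyond the scatter), so the number does not rise evenly as the chain shortens across these four compounds. Nothing measured here explains the sharp rise at methoxy.

From the compounds shown here alone, how a propoxy group would compare with ethoxy remains open. So does whether an amine or a carboxylic acid carried on the chain would keep the number low.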